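The source may report more compounds than this note shows. Statements on the series, on what has been measured and on what is new or still open speak of the compounds shown alone.

Measured so far in an ADME assay on microsomes from liver (Rattus norvegicus) for metabolic stability (a higher number here means that the compound lasts longer, a lower number that the compound disappears faster), are three compounds
Compound 1 `CCC(CC)(c1nnc[nH]1)c1ccc(-c2ccc3cc(F)cc(F)c3c2)[nH]c1=O` gives 1.26 h
Compound 2 `CC(C)C(c1ccc(-c2ccc3cccc(F)c3c2)[nH]c1=O)N1CCN/C1=N\C#N` gives 0.327 h
Compound 3 `CCC(CC)(c1nnc[nH]1)c1ccc(-c2ccc3cccc(F)c3c2)[nH]c1=O` gives 0.925 h

Compound 2 sits lowest of the three, and its gaps to compound 1 and compound 3 both lie beyond the usual scatter. Compound 4 `CC(C)C(c1noc(=O)[nH]1)c1ccc(-c2ccc3cccc(F)c3c2)[nH]c1=O` has not been measured yet. It differs from compound 2 in one group, as follows a group of 6 heavy atoms (2 carbon, 2 nitrogen, 2 oxygen; one five-membered aromatic ring with 3 hetero atoms) in place of a group of 8 heavy atoms (4 carbon, 4 nitrogen; one five-membered non-aromatic ring with 2 hetero atoms), on a saturated chain carbon bound to an aromatic carbon and a saturated chain carbon and the rest of the molecule stays the same.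

Among the measured compounds shown here, the only measured step between close relatives is a 1.4-fold lower number from compound 1 to compound 3 (0.13 log units; within the scatter) and it concerns a fluoro swap, so it says nothing direct about this exchange of groups. Compound 2 shares its core with compound 3 and, with different groups on the chain carbon, compound 3 gives 0.925 h as a hint that the number can move when that part changes. This is thin evidence. In this assay only a small upward step is therefore expected, a 1.7-fold higher number from compound 2 to compound 4 (0.23 log units; within the scatter) and it may stay within the scatter. For compound 4 the estimated half-life is 0.55 h with an expected range from 0.25 h to 1.2 h as a rough guide.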

Compound 4, half-life: > 3 h
Compound 4 gave a limit, no number; the forecaster's own chance of this, stated with the estimate: 3%; middle value at least 5.4-fold (0.73 log units) from the limit.
By their numbers in this assay, from the lowest: compound 2; then compounds 3 and 1 (each within the scatter of the next). At a limit, above all of these: compound 4.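

In this assay, among the compounds shown here, the group on the saturated chain carbon bound to an aromatic carbon and a saturated chain carbon proves able to shift the half-life far more than the fluoro swap among the earlier compounds did, with an at least 9.1-fold higher number from compound 2 to compound 4 (0.96 log units; beyond the scatter) for the exchange of the five-membered non-aromatic ring group for the five-membered aromatic ring group. Compound 4 gives > 3 h, which is a limit of the assay and not a number. The step can be read only as a minimum because the reading for compound 4 ends at a limit: the limit of > 3 h in this assay, at which 1 of the 4 values shown sits.

With a single pair, it remains open which part of the exchanged group accounts for the step. Also open, going by these compounds, is how a carboxylic acid or an amine on the same saturated chain carbon would behave in this assay.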